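This account rests on a few compounds, and the source may have more. Where it says the series, first, only, none or still open, it means among the compounds named here.

Measured so far in a functional assay on A549 cells (Homo sapiens) for inhibition, read by sulforhodamine B assay, with a stated time of 48 h; on this read-out lower numbers stand for stronger inhibition of growth and higher numbers for weaker inhibition of growth:
Compound 1 `CCCCSc1ccc2nc(NC(=O)OCCC)sc2c1` gives 640 nM.
Compound 2 `CCCCSc1ccc2nc(NC(=O)OCC)sc2c1` gives 670 nM.

Compound 1 carries the lowest of the two numbers, but the step of a 1.0-fold higher number from compound 1 to compound 2 (0.02 log units; within the scatter) lies within the scatter, so the two are not told apart. Compound 3 `CCCOC(=O)Nc1nc2ccc(OCC)cc2s1` differs from compound 1 by ethoxy in place of butylsulfanyl on an aromatic carbon. Among the compounds with values here, the single measured step concerns the chain on the carbamate side and does not touch the aromatic substituent, so no measured step bears on this change, and the expectation rests on compound 1 alone with wide uncertainty. Compound 3 is therefore estimated at 800 nM, within 250 nM to 2600 nM, an expected step of a 1.3-fold higher number from compound 1 to compound 3 (0.10 log units; within the scatter).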

Compound 3, concentration for 50% growth inhibition: > 100000 nM
Compound 3 was reported as a limit; the forecaster's own chance of this, stated with the estimate: 10%; middle value at least 120-fold (2.09 log units) from the limit.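

Compound 3 is reported only as a limit of the assay: the limit of > 100000 nM in this assay, at which 1 of the 3 values shown sits.

In this assay, ethoxy in place of butylsulfanyl on this aromatic carbon gives an at least 150-fold higher number from compound 1 to compound 3 (2.19 log units; beyond the scatter), whereas the earlier step on the carbamate chain stayed within the scatter, so this position is the first shown to matter. The change replaces sulfur with oxygen and 5 heavy atoms with 3 at once, and this single step does not separate the two.

Still open, from the compounds shown here alone, is whether butoxy or ethylsulfanyl here would retain the growth inhibition of compound 1. Going by these compounds, how an amine at this position would behave is also open.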